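A few compounds are considered here, and "the series" means these few. Any claim that something is new, unique, unknown or untested is made for them only; others in the source may bear on it.

Of the compounds shown here, two with a shared core have been measured in a functional assay on SK-MEL-5 cells (Homo sapiens) for inhibition, read by sulforhodamine B assay, with a stated time of 48 h; on this read-out higher numbers stand for weaker inhibition of growth and lower numbers for stronger inhibition of growth. Compound 1 `COc1cc(-c2cc(/C=C/C(=O)c3ccc(Cl)c(Cl)c3)[nH]n2)cc(OC)c1OC` gives 46900 nM, and compound 2 `COc1ccc(C(=O)/C=C/c2cc(-c3cc(OC)c(OC)c(OC)c3)n[nH]2)cc1OC` gives 3030 nM. For the measured compounds named here, the one step between them, a 15-fold lower number from compound 1 to compound 2 (1.19 log units; beyond the scatter), comes from swapping the aryl group on the carbonyl carbon. Going by the values given here, on these two numbers compound 2 stands lowest, with compound 1 as its only neighbour.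

Compound 3 `COc1cc(C(=O)/C=C/c2cc(-c3cc(OC)c(OC)c(OC)c3)n[nH]2)cc(OC)c1OC` differs from compound 2 only at that same aryl group: methoxy in place of hydrogen on an aromatic carbon. Among the compounds with values here, no measured step tests this particular addition; the step of a 15-fold lower number from compound 1 to compound 2 (1.19 log units; beyond the scatter) concerns a different exchange at the same position and so gives only weak guidance. The expected step in this assay is therefore small and its direction uncertain, set here as a 1.2-fold lower number from compound 2 to compound 3 (0.08 log units; within the scatter). Compound 3 is estimated at 2500 nM, with a range from 700 nM to 9000 nM.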

Compound 3, concentration for total growth inhibition: 2940 nM
For compound 3 the middle estimate is 1.2-fold (0.07 log units) below the measured one; the range from low to high includes it.
By their numbers in this assay, from the lowest: compounds 3 and 2 (each within the scatter of the next); then compound 1.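

In this assay, adding a methoxy group to the aryl ring on the carbonyl carbon, ortho to a methoxy group already there, gives a 1.0-fold lower number from compound 2 to compound 3 (0.01 log units; within the scatter) and so leaves the number effectively unchanged. The exchange of aryl groups at this same place gave a 15-fold lower number from compound 1 to compound 2 (1.19 log units; beyond the scatter) and so moved the number far more, which shows that not every change here counts: with two methoxy groups already on this ring, a further one adds nothing that this read-out can detect. Nothing measured here explains why the addition makes no difference.

Still open, from the compounds shown here alone, is whether an amine or a carboxylic acid at this ring carbon would move the number, or whether a longer chain such as ethoxy would. The compounds shown also leave open how a change on the other aryl group of the shared core would read.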